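Replacing the Amino Link at the Carbonyl of Compound 1

The source may report more compounds than this note shows. Statements on the series, on what has been measured and on what is new or still open speak of the compounds shown alone.

Compound 1 `COc1cc(Cl)cc(-c2nn(-c3cccc(NC(=O)Nc4cccc(C(F)(F)F)c4)c3)cc2-c2ccncc2)c1` shows the lowest number of the three measured compounds in a functional assay on MCF7 cells (Homo sapiens) for inhibition, read by sulforhodamine B assay, with a stated time of 48 h, tested at 10 uM (a lower number here means a stronger effect, a higher number a weaker effect of the compound at the concentration tested), where compound 1 gives 0.3%. Compound 2 `COc1cc(Cl)cc(-c2nn(-c3cccc(NC(=O)Nc4ccc(Cl)c(C(F)(F)F)c4)c3)cc2-c2ccncc2)c1` gives 2.57%, and the step of a number 2.3 percentage points higher from compound 1 to compound 2 (within the scatter) stays within the usual scatter. Among the measured compounds shown here, compound 3 `COc1cc(Cl)cc(-c2nn(-c3cccc(NC(=O)c4cc(C(F)(F)F)cc(C(F)(F)F)c4)c3)cc2-c2ccncc2)c1` gives 57.8%, a far weaker effect than compound 1; compound 3 carries its aryl group directly on the carbonyl rather than through an amino link, but it also bears a different aryl, so no single-change step joins it to compound 1.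

Compound 4 `COc1cc(Cl)cc(-c2nn(-c3cccc(NC(=O)c4ccc(Cl)c(Cl)c4)c3)cc2-c2ccncc2)c1` has not yet been measured. It differs from compound 1 by 3,4-dichlorophenyl in place of (3-(trifluoromethyl)phenyl)amino on a carbonyl carbon. For the measured compounds named here, the only single-change step, from compound 1 to compound 2, concerns a chloro on the aryl and does not bear on removing the amino link. Going by the values given here, the values of compound 1 at 0.3% and compound 3 at 57.8% show that the one measured compound with an aryl directly on the carbonyl is much weaker. A large step toward a weaker effect is therefore expected in this assay, a number 39.7 percentage points higher from compound 1 to compound 4 (beyond the scatter). Compound 4 is estimated to give 40%, within a range from 8% to 75%.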

Compound 4, a percentage reported as activity, at one concentration (the size of the read-out at that concentration, not a potency): 57.7%
Beside the measured number, compound 4's estimate is 17.7 percentage points below it; the range from low to high includes it.
By their numbers in this assay, from the lowest: compounds 1 and 2 (each within the scatter of the next); then compounds 4 and 3 (each within the scatter of the next).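

In this assay, placing 3,4-dichlorophenyl on the carbonyl carbon in place of the substituted phenylamino group gives a large step of a number 57.4 percentage points higher from compound 1 to compound 4 (beyond the scatter) and, from the chlorinated urea partner, one of a number 55.1 percentage points higher from compound 2 to compound 4 (beyond the scatter) in the same direction. Compound 3 gives 57.8% and compound 4 gives 57.7% within the scatter of each other, so two different aryl groups set directly on the carbonyl now give one shared level, far weaker than the two compounds that keep the amino link. Nothing available here bears on why the effect falls.

From the compounds shown here alone, each step changes both the link and the aryl substituents, so the share of the amino link alone stays open. A methylene group or an ether oxygen as the link, with the 3-(trifluoromethyl)phenyl ring kept, would be needed to separate the two changes.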